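Amine substituent variation on a 5-hydroxytryptamine receptor 1D series

The compounds below may be only part of what the source reports. "The series", "measured", "known", "first", "only" and "open" are said of these compounds alone.

Measured so far in a functional assay on CHO cells for agonist activity at 5-hydroxytryptamine receptor 1D (Homo sapiens), read by GTPgammaS binding; a lower number here means that less compound is needed, a higher number that more compound is needed for the effect:
compound 1 `CC(C)(C)OC(=O)NCC1(O)CCN(CCCc2c[nH]c3ccc(-n4cnnc4)cc23)CC1` gives 9.7 nM
compound 2 `CC(=O)Nc1ccc(CNCC2(O)CCN(CCCc3c[nH]c4ccc(-n5cnnc5)cc34)CC2)cc1` gives 14 nM

Compound 2 holds the higher of the two numbers, but the step of a 1.4-fold higher number from compound 1 to compound 2 (0.16 log units; within the scatter) is within the scatter, so the two compounds are not separable here. For the measured compounds named here, the single measured step thus bears on the question of what the amine substituent tolerates and points to a small or no effect. Compound 3 `Cc1ccccc1CN(C)CC1(O)CCN(CCCc2c[nH]c3ccc(-n4cnnc4)cc23)CC1` carries methyl(2-methylbenzyl)amino in place of (4-acetamidobenzyl)amino on a saturated chain carbon bound to a saturated ring carbon. Going by the values given here, no further step informs this change. Compound 3 is expected to show a step of a 1.1-fold higher number from compound 2 to compound 3 (0.03 log units; within the scatter), estimated at 15 nM with a range from 5 nM to 50 nM.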

Compound 3, concentration for half-maximal effect: 3.7 nM
The estimate for compound 3 lay 4.1-fold (0.61 log units) above the measured number; the whole stated range lies above it.
By their numbers in this assay, from the lowest: compound 3; then compounds 1 and 2 (each within the scatter of the next).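

In this assay, this position on a saturated chain carbon bound to a saturated ring carbon proves responsive to its substituent: methyl(2-methylbenzyl)amino gives steps beyond the scatter (a 3.8-fold lower number from compound 2 to compound 3 (0.58 log units; beyond the scatter)) and (a 2.6-fold lower number from compound 1 to compound 3 (0.42 log units; beyond the scatter)). The earlier substituent change did not leave the scatter. Nothing available accounts for the lower number.

Each step changes several features at once, so the share of the amine methyl, the 2-methyl group and the lost acetamido or tert-butoxycarbonyl group stays unresolved. Plain benzylamino and methyl(benzyl)amino groups would separate these contributions.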